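This account rests on a few compounds, and the source may have more. Where it says the series, first, only, none or still open, it means among the compounds named here.

Measured so far:

Compound 1 `Cc1nn(-c2ccccn2)c2cc(-c3ccc(CCC(=O)O)cc3)ccc12` in a functional assay on cells for agonist activity at Free fatty acid receptor 1 (Mus musculus), read by FLIPR and calcium flux, with a stated time of 5 min (a lower number here means a smaller maximal response, a higher number a larger maximal response), gives 95%.
Compound 2 `O=C(O)CCc1ccc(-c2ccc3cnn(-c4ccccn4)c3c2)cc1` gives 106%.
Compound 3 `COc1nn(-c2ccccn2)c2cc(-c3ccc(CCC(=O)O)cc3)ccc12` gives 96%.

All three compounds share one core and differ only in the group on a five-membered aromatic ring with two nitrogen. Compound 3 sits in the middle of the three numbers; its neighbours are within the usual scatter on either side, so the three maximal responses cannot really be told apart.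

Compound 4 `CCc1nn(-c2ccccn2)c2cc(-c3ccc(CCC(=O)O)cc3)ccc12` is the next compound. Its change from compound 3 is this: ethyl in place of methoxy on an aromatic carbon

Within the data shown here, two measured steps touch the same place. From methyl to methoxy the change was a number 1 percentage points higher from compound 1 to compound 3 (within the scatter), and from methyl to hydrogen it was a number 11 percentage points higher from compound 1 to compound 2 (beyond the scatter), while a number 10 percentage points lower from compound 2 to compound 3 (within the scatter). Three rather different groups at this position therefore all gave much the same maximal response, with only the bare hydrogen nudging the number up a little. Ethyl has not been tried, but nothing in these steps points to a large move in either direction, so for compound 4 the expected step is no change at the digits printed from compound 3 to compound 4 (within the scatter), within the scatter.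

The estimate for compound 4 in this assay is therefore 96%, expected to lie between 85% and 107%.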

Compound 4, largest response reached (reported as efficacy), in percent of the reference or control that the assay uses: 93%
Compound 4: middle estimate off by 3 percentage points, on the high side; measured number inside the range.
By their numbers in this assay, from the lowest: compounds 4, 1, 3 and 2 (each within the scatter of the next, the first and the last beyond it).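

In this assay the swap from methoxy to ethyl, which takes away that group's oxygen and its one hydrogen-bond acceptor, gives no readable change (a number 3 percentage points lower from compound 3 to compound 4 (within the scatter)). Lengthening methyl to ethyl by one saturated carbon gives no readable change either (a number 2 percentage points lower from compound 1 to compound 4 (within the scatter)), so among these three groups neither the oxygen nor the extra carbon shows up in the maximal response. Among these compounds, the only new step beyond the scatter is the one from the bare hydrogen (a number 13 percentage points lower from compound 2 to compound 4 (beyond the scatter)), a modest gap like the one from methyl to hydrogen, although compound 3 stays within the scatter of compound 2, so having a group here rather than hydrogen separates the compounds only in part.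

The compounds shown leave open whether a group of another kind at this position, such as an amine, a carboxylic acid or a longer chain, would keep the maximal response in this same range. Nothing available here explains why these groups give such similar responses.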